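A Chlorinated, Trifluoromethylated Phenyl on the Aromatic Nitrogen

This account rests on a few compounds, and the source may have more. Where it says the series, first, only, none or still open, it means among the compounds named here.

- Compound 1 `Cn1ccc2c(Oc3ccc(NC(=O)c4cc5cccnc5n(-c5ccccc5)c4=O)cc3)ncnc21` gives 88400 nM
- Compound 2 `Cn1ccc2c(Oc3ccc(NC(=O)c4cc5cccnc5n(-c5ccc(C(F)(F)F)cc5Cl)c4=O)cc3)ncnc21` gives "not active" (no number reported)
- Compound 3 `Cn1ccc2c(Oc3ccc(NC(=O)c4cc5cccnc5n(-c5ccccc5)c4=O)cc3F)ncnc21` gives 73400 nM

In a functional assay on MCF7 cells (Homo sapiens) for cytotoxicity, read by MTT assay, with a stated time of 72 h (on this read-out lower numbers stand for stronger inhibition and higher numbers for weaker inhibition), compound 3 gives 73400 nM as its result, within the usual scatter of compound 1, and compound 2 yields no number to compare. Compound 4 `Cn1ccc2c(Oc3ccc(NC(=O)c4cc5cccnc5n(-c5ccc(C(F)(F)F)c(Cl)c5)c4=O)cc3F)ncnc21` has 3-chloro-4-(trifluoromethyl)phenyl in place of phenyl on an aromatic nitrogen. Among the measured compounds shown here, the only measured step is a 1.2-fold lower number from compound 1 to compound 3 (0.08 log units; within the scatter) and it concerns fluoro in place of hydrogen, so it does not test this swap. Compound 2 also carries chloro and trifluoromethyl on its phenyl, which gives a weak hint towards higher numbers. The expected change in this assay is a 1.1-fold higher number from compound 3 to compound 4 (0.04 log units; within the scatter) and so nothing clear beyond the scatter. For compound 4 the estimated value is 80000 nM with an expected range of 25000 nM to 200000 nM here.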

Compound 4, half-maximal inhibitory concentration: "not active" (no number reported)
Compound 4 has no reported number here, and the estimate cannot be compared.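

Among the compounds shown here, compound 4 is reported as not active with no number, so no step from compound 3 to compound 4 can be read. No other data here bear on this result. As far as these compounds go, how far 3-chloro-4-(trifluoromethyl)phenyl in place of phenyl shifts the number stays open.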